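Nitrocatechol chalcones: swapping a thiazole for a methylpyrazole

A few compounds are considered here, and "the series" means these few. Any claim that something is new, unique, unknown or untested is made for them only; others in the source may bear on it.

Measured compounds:
compound 1 `O=C(/C=C/c1nccs1)c1cc(O)c(O)c([N+](=O)[O-])c1` — 240 nM
compound 2 `N#Cc1ccc(/C=C/C(=O)c2cc(O)c(O)c([N+](=O)[O-])c2)cc1` — 180 nM
compound 3 `CC(=O)N1N=C(c2cc(O)c(O)c([N+](=O)[O-])c2)CC1c1ccc(C#N)cc1` — 48 nM

Of the compounds shown here, three built on the same nitrocatechol core have been tested in an assay for inhibition of Catechol O-methyltransferase (Rattus norvegicus), read by fluorescence and spectrophotometry; on this read-out lower numbers stand for stronger inhibition and higher numbers for weaker inhibition. Compound 1 gives 240 nM, the highest of the three numbers. Compound 2 gives 180 nM, which lies within the scatter of the number for compound 1, so the two cannot be told apart. Compound 3, in which the chain is closed into an acetylated pyrazoline, gives 48 nM, a lower number than compound 1 by a margin beyond the scatter.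

The next compound keeps the open enone chain of compound 1 and changes only the ring at its far end: compound 4 `Cn1cc(/C=C/C(=O)c2cc(O)c(O)c([N+](=O)[O-])c2)cn1` carries 1-methyl-1H-pyrazol-4-yl in place of 1,3-thiazol-2-yl on a double-bonded chain carbon bound to a double-bonded chain carbon. For the measured compounds named here, no measured pair shows what this kind of ring swap does on this core; the nearest hint is that compound 1 and compound 2, whose end rings differ far more, sit within the scatter of each other. The step from compound 1 to compound 4 is therefore expected to be small, a 1.0-fold higher number from compound 1 to compound 4 (0.02 log units; within the scatter), with no firm direction. Compound 4 is estimated at 250 nM, with a likely range from 100 nM to 600 nM.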

Compound 4, half-maximal inhibitory concentration: 290 nM
Compound 4: middle estimate off by 1.2-fold (0.06 log units), on the low side; the range from low to high includes it.
By their numbers in this assay, from the lowest: compound 3; then compounds 2, 1 and 4 (each within the scatter of the next).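

Replacing 1,3-thiazol-2-yl with 1-methyl-1H-pyrazol-4-yl on a double-bonded chain carbon bound to a double-bonded chain carbon, this assay shows a 1.2-fold higher number from compound 1 to compound 4 (0.08 log units; within the scatter) and so no change in inhibition that can be told from the usual scatter. This is the first pair among the compounds shown that differ in one place, and it shows directly that the open enone chain can carry either of these two five-membered aromatic rings with no measurable consequence in this assay, where before only the much less closely related end rings of compound 1 and compound 2 hinted at such tolerance. Nothing available explains why the two rings give numbers that cannot be told apart.

The compounds shown leave open whether an amine or a carboxylic acid on the end ring, or a longer chain in place of the methyl, would move the number beyond the scatter. They also leave open whether 1-methyl-1H-pyrazol-4-yl would be tolerated equally well on the acetylated pyrazoline of compound 3.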